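Anilide variation on the shared linker core

The compounds below may be only part of what the source reports. "The series", "measured", "known", "first", "only" and "open" are said of these compounds alone.

Of the compounds shown here, three with the shared core have been measured in a functional assay on HCT-116 cells (Homo sapiens) for inhibition, read by colorimetric assay, with a stated time of 3 days; on this read-out higher numbers stand for weaker inhibition and lower numbers for stronger inhibition. Compound 1 `O=C(CCCCCCNC(=O)C(O)(O)C(F)(F)F)Nc1ccccc1Br` gives 14500 nM in this assay, the highest of the three numbers. Compound 3 `O=C(CCCCCCNC(=O)C(O)(O)C(F)(F)F)Nc1ncc(-c2ccccc2)s1` gives 2660 nM in this assay, the nearest to compound 1, and compound 2 `COc1ccc2sc(NC(=O)CCCCCCNC(=O)C(O)(O)C(F)(F)F)nc2c1` gives 2180 nM in this assay; both differences from compound 1 lie beyond the scatter, so compound 1 stands as the weakest inhibitor measured so far.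

Compound 4 `COc1cccc(NC(=O)CCCCCCNC(=O)C(O)(O)C(F)(F)F)c1` keeps the core and differs from compound 1 in one place: 3-methoxyphenyl in place of 2-bromophenyl on an amide-type nitrogen. Within the data shown here, no measured pair isolates this change, and the amine-bearing groups of compounds 2 and 3 are of another kind, so their values do not fix its direction. Among the measured compounds shown here, the only guide is that compound 1 sits at the weak end, which leaves room for a lower number but does not require one. In this assay the step expected is a 1.6-fold lower number from compound 1 to compound 4 (0.21 log units; within the scatter), a modest decrease at most and quite possibly within the scatter. Compound 4 is accordingly expected to give about 9000 nM in this assay, within a range from 3000 nM to 30000 nM.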

Compound 4, half-maximal inhibitory concentration: 6110 nM
Beside the measured number, compound 4's estimate is 1.5-fold (0.17 log units) above it, within the range that was stated.
By their numbers in this assay, from the lowest: compounds 2 and 3 (each within the scatter of the next); then compound 4; then compound 1.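

The aryl group on this amide-type nitrogen is not a silent position: with the rest of the shared core unchanged, 3-methoxyphenyl in place of 2-bromophenyl gives a 2.4-fold lower number from compound 1 to compound 4 (0.38 log units; beyond the scatter) in this assay. This is the only comparison among the compounds shown that isolates a single place, so the effect of this group can be read directly here, whereas the earlier values could only be set side by side. The two groups differ at once in the substituent, in the numbered ring position it occupies and in the count of hydrogen-bond acceptors, so this single step does not assign the change to any one of these. No independent measurement bears on the origin of the step.

Still open, as far as these compounds go, is whether 3-bromophenyl or 2-methoxyphenyl would separate the substituent from its ring position, and where an unsubstituted phenyl would stand against both groups. Also open, from the compounds shown here alone, is whether the step holds with a shorter or longer linker chain, or with a carboxylic acid in place of the trifluoromethyl-bearing end.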